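Swapping the ketone for a methylamide on the shared core

The source may report more compounds than this note shows. Statements on the series, on what has been measured and on what is new or still open speak of the compounds shown alone.

Compound 1: `COC(=O)c1cc2cc(NCc3cc(NC(=O)c4ccc(CN5CCC(N(C)C)C5)c(C(F)(F)F)c4)ccc3C)cnc2[nH]1` — 689 nM
Compound 2: `CC(=O)c1cc2cc(NCc3cc(NC(=O)c4ccc(CN5CCC(N(C)C)C5)c(C(F)(F)F)c4)ccc3C)cnc2[nH]1` — 97 nM
Compound 3: `CNC(=O)c1cc2cc(NCc3cc(NC(=O)c4ccc(CN5CCN(C)CC5)cc4)ccc3C)cnc2[nH]1` — > 1000 nM
Compound 4: `CNC(=O)c1cc2cc(NCc3cc(NC(=O)c4ccc(CN5CCC(N(C)C)C5)c(C(F)(F)F)c4)ccc3C)cnc2[nH]1` — not yet measured

Of the compounds shown here, three have been tested in a functional assay on HUVEC cells (Homo sapiens), read by MTT assay, with a stated time of 72 h; on this read-out lower numbers stand for an effect already at smaller amounts and higher numbers for an effect only at larger amounts of compound. Compound 1 carries a methyl ester on the shared core and gives 689 nM. Compound 2 carries an acetyl group in the same place and gives 97 nM, the lowest of the two numbers recorded so far. For the measured compounds named here, the step between them, a 7.1-fold lower number from compound 1 to compound 2 (0.85 log units; beyond the scatter), is the only measured step in this set. Compound 3, which has a methylcarbamoyl group on the core but a different amine portion and no trifluoromethyl, reaches only the limit of the limit of > 1000 nM in this assay, at which 1 of the 3 values shown sits, in this assay; this is a limit, not a number.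

Compound 4 is built from compound 2 by one change: methylamino in place of methyl on a carbonyl carbon. Going by the values given here, this is the same group that compound 3 carries, but no measured step isolates that group on its own, so the comparison rests on the value of compound 3 and on the direction seen from compound 1 to compound 2. Because the value > 1000 nM of compound 3 sits at the limit, a higher number than compound 2 is expected for compound 4, with the step of a 4.6-fold higher number from compound 2 to compound 4 (0.67 log units; beyond the scatter) estimated. For compound 4 the expected value in this assay is 450 nM, with a range from 100 nM to 2000 nM.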

Compound 4, half-maximal effective concentration: 83 nM
The estimate for compound 4 lay 5.4-fold (0.73 log units) above the measured number; measured number below the stated range.
By their numbers in this assay, from the lowest: compounds 4 and 2 (each within the scatter of the next); then compound 1. At a limit, above all of these: compound 3.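

In this assay, methylamino in place of methyl on the carbonyl carbon gives a 1.2-fold lower number from compound 2 to compound 4 (0.07 log units; within the scatter), so on this core the acetyl and methylcarbamoyl groups cannot be told apart, even though the change brings in the amide hydrogen as a hydrogen-bond donor. The clear separation at this place lies with the methyl ester instead, as methylamino in place of methoxy gives an 8.3-fold lower number from compound 1 to compound 4 (0.92 log units; beyond the scatter), a step that points the same way as a 7.1-fold lower number from compound 1 to compound 2 (0.85 log units; beyond the scatter). Compound 3 also carries the methylcarbamoyl group, yet its result remains a limit and not a number: the limit of > 1000 nM in this assay, at which 1 of the 4 values shown sits.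

Compound 3 differs from the other compounds in more than one place, so its steps cannot be read, and the data cannot separate the roles of its amine portion and of the missing trifluoromethyl group. Also open, on these data alone, is whether a carboxylic acid, a dimethylamino group or a longer chain such as ethylamino on this carbonyl carbon would stay within the scatter of compound 4 at 83 nM or would move away from it.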